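The source may hold more compounds than are shown below. What is called first, only, known or untested is meant among the compounds shown, and "the series" means these compounds.

Measured so far:

Compound 1 `C=CCOc1ccc(F)cc1C(=O)c1cccnc1`. In a functional assay on PC-3 cells (Homo sapiens) for cytotoxicity, read by sulforhodamine B assay, with a stated time of 48 h (on this read-out higher numbers stand for weaker inhibition and lower numbers for stronger inhibition), compound 1 gives > 100000 nM, which is a limit of the assay and not a number.

Compound 2 `C=CCOc1ccc(Cl)cc1C(=O)c1cccnc1`. In this assay compound 2 gives > 100000 nM, again a limit of the assay rather than a number.

Among the measured compounds shown here, compound 2 therefore stands at the top end of what has been recorded, and the only other value sits at the same place: the limit of > 100000 nM in this assay, at which 2 of the 2 values shown sit. For the measured compounds named here, the single measured step within the pair, a step that the two limits leave unreadable from compound 1 to compound 2, gives no size and no direction, since both ends are limits.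

Compound 3 `C=CCOc1ccccc1C(=O)c1cccnc1` differs from compound 2 by hydrogen in place of chloro on an aromatic carbon. Going by the values given here, no measured step reads on this change; the one step available, chloro for fluoro, is unreadable, so there is no anchor for the size of the step in this assay. With both measured compounds at the limit, the expectation is that compound 3 also returns a limit rather than a number, and no shift beyond the scatter is expected in either direction. Compound 3 is accordingly estimated at 100000 nM, with a range of 30000 nM to 300000 nM. This estimate means a step of a number no higher from compound 2 to compound 3 (the limit leaves the size open) is expected.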

Compound 3, half-maximal inhibitory concentration: 55000 nM
Beside the measured number, compound 3's estimate is 1.8-fold (0.26 log units) above it, within the range that was stated.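

Hydrogen on this aromatic carbon, para to an allyloxy group, gives the first reading in this assay that is a number and not a limit, so the series now has a measured value to work from. The change to hydrogen reads as an at least 1.8-fold lower number from compound 2 to compound 3 (0.25 log units; that floor lies within the scatter), and the same change in place of fluoro reads as an at least 1.8-fold lower number from compound 1 to compound 3 (0.25 log units; that floor lies within the scatter). Each figure is a floor only, with the true size open on the side of a larger step, and the chloro and fluoro compounds still cannot be ranked against each other, their step being unreadable: the limit of > 100000 nM in this assay, at which 2 of the 3 values shown sit.

As far as these compounds go, how far either halogen really lies from hydrogen at this carbon stays open, and so does the effect of an amine, a methoxy group or a carboxylic acid there, with a number on both sides of the step still needed. Also open, from the compounds shown here alone, is whether the reading of compound 3 holds when the allyloxy group gives way to a longer chain or an amine on the shared core.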